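Removing the chloro group from compound 2

A few compounds are considered here, and "the series" means these few. Any claim that something is new, unique, unknown or untested is made for them only; others in the source may bear on it.

In an assay on CHO-K1 cells for binding affinity to muscarinic acetylcholine receptor M5 (Homo sapiens) (on this read-out lower numbers stand for stronger inhibition and higher numbers for weaker inhibition), compound 2 `CCC(C1=C(CCN(C)C)Cc2cc(Cl)ccc21)c1ccccn1` gives 776 nM, and compound 1 `CC(C1=C(CCN(C)C)Cc2cc(Cl)ccc21)c1ccccn1` gives 724 nM in this assay. Compound 2 stands alongside compound 1, the two numbers within the scatter of each other. For the measured compounds named here, the only measured step, a 1.1-fold higher number from compound 1 to compound 2 (0.03 log units; within the scatter), concerns the saturated chain and was within the scatter. Compound 3 `CCC(C1=C(CCN(C)C)Cc2ccccc21)c1ccccn1` differs from compound 2 by hydrogen in place of chloro on an aromatic carbon. No measured step touches the aromatic ring, so nothing shown bears directly on this change. For compound 3 the expected step is a 1.5-fold higher number from compound 2 to compound 3 (0.19 log units; within the scatter), small and toward a higher number. Compound 3 is therefore estimated at 1200 nM, within 450 nM to 3200 nM.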

Compound 3, inhibition constant: 676 nM
For compound 3 the middle estimate is 1.8-fold (0.25 log units) above the measured one, within the range that was stated.
By their numbers in this assay, from the lowest: compounds 3, 1 and 2 (each within the scatter of the next).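

Hydrogen in place of chloro is the first change on the aromatic ring in this series, and in this assay it gives a 1.1-fold lower number from compound 2 to compound 3 (0.06 log units; within the scatter). On the background of compound 2, the read-out therefore does not depend on keeping chloro at this aromatic carbon. Nothing available accounts for this result.

As far as these compounds go, whether any group at this carbon moves the number beyond the scatter remains open, for example fluoro, methoxy or an amine. Also open, from the compounds shown here alone, is whether a longer chain in place of the dimethylamino end would do so.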